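A ring swap at the assay limit

The source may report more compounds than this note shows. Statements on the series, on what has been measured and on what is new or still open speak of the compounds shown alone.

Measured in a functional assay on NALM-6 cells (Homo sapiens) for cytotoxicity, with a stated time of 72 h; on this read-out lower numbers stand for an effect already at smaller amounts and higher numbers for an effect only at larger amounts of compound:
compound 1 `C=C[C@@](C)(/C=C/c1ccc(Nc2ccc(OC)cc2)cc1)CCC=C(C)C`: > 43400 nM
compound 2 `C=C[C@@](C)(/C=C/c1ccc(Nc2ccc(OC(F)(F)F)cc2)cc1)CCC=C(C)C`: > 43400 nM

In this assay compound 1 gives > 43400 nM, which is a limit of the assay and not a number. Compound 2 gives > 43400 nM, which is also a limit. The evidence therefore comes to a single observation: the limit of > 43400 nM in this assay, at which 2 of the 2 values shown sit.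

The next compound is compound 3 `C=C[C@@](C)(/C=C/c1ccc(Nc2cc(F)c(F)cc2F)cc1)CCC=C(C)C`, which keeps the core of compound 1 and changes the group on the nitrogen: 2,4,5-trifluorophenyl in place of 4-methoxyphenyl on a nitrogen on an aromatic ring. In words, 2,4,5-trifluorophenyl stands in place of 4-methoxyphenyl.

Within the data shown here, the one measured step that bears on this change is a step that the two limits leave unreadable from compound 1 to compound 2. It also alters the 4-methoxyphenyl group, but it has no readable size, so no measured amount can be carried over to compound 3. With nothing measured as a number, no step beyond the scatter is expected in this assay, in either direction, and another limit is the likeliest report.

For compound 3 the expected value is 50000 nM, with an estimated range from 25000 nM to 100000 nM.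
The expected change is a step that the limit leaves unreadable from compound 1 to compound 3.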

Compound 3, half-maximal effective concentration: > 43400 nM
Compound 3: no number, only a limit; the forecaster's own chance of this, stated with the estimate: 85%; the middle value does not contradict the limit.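

In this assay compound 3 gives > 43400 nM, which is a limit and not a number. Among these compounds, no step among compound 1, compound 2 and compound 3 can be read. The compounds shown leave open whether changing the group on the nitrogen alters the effect on these cells at all, in either direction: the limit of > 43400 nM in this assay, at which 3 of the 3 values shown sit.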